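A few compounds are considered here, and "the series" means these few. Any claim that something is new, unique, unknown or untested is made for them only; others in the source may bear on it.

In a functional assay on MOLT-4 cells (Homo sapiens) for antiproliferative activity (a lower number here means a stronger inhibitor, a higher number a weaker inhibitor), compound 1 (`COc1cc(C(=O)c2sc(-c3ccsc3)cc2N)cc(OC)c1OC`) gives 8.8 nM, compound 2 (`COc1cc(C(=O)c2sc(-c3ccc(F)cc3)cc2N)cc(OC)c1OC`) gives 12 nM and compound 3 (`COc1cccc(-c2cc(N)c(C(=O)c3cc(OC)c(OC)c(OC)c3)s2)c1`) gives 17 nM. Compound 3 therefore stands within the scatter of both others. Compound 4 (`COc1cc(C(=O)c2sc(-c3cccs3)cc2N)cc(OC)c1OC`) is not yet measured. It carries thiophen-2-yl in place of 3-methoxyphenyl on an aromatic carbon. Within the data shown here, two measured steps bear directly on this swap: a 1.9-fold higher number from compound 1 to compound 3 (0.29 log units; within the scatter) and a 1.4-fold higher number from compound 2 to compound 3 (0.15 log units; within the scatter). Compound 1, with thiophen-3-yl, is the nearest comparison, and a 1.4-fold higher number from compound 1 to compound 2 (0.13 log units; within the scatter) adds a further exchange of aromatic groups. No step beyond the scatter is therefore expected in this assay. The expected step is a 1.4-fold lower number from compound 3 to compound 4 (0.15 log units; within the scatter). The estimate for compound 4 is 12 nM, with an expected range of 5 nM to 30 nM.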

Compound 4, half-maximal inhibitory concentration: 8.9 nM
Beside the measured number, compound 4's estimate is 1.3-fold (0.13 log units) above it; the measured number falls inside the stated range.
By their numbers in this assay, from the lowest: compounds 1, 4, 2 and 3 (each within the scatter of the next).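

In this assay, moving the attachment point of the thiophene on this aromatic carbon next to the ring sulfur gives no readable change (a 1.0-fold higher number from compound 1 to compound 4 (0.00 log units; within the scatter)). The five-membered aromatic ring with sulfur also stays within the scatter of both six-membered aromatic rings of carbon only (a 1.3-fold lower number from compound 2 to compound 4 (0.13 log units; within the scatter); a 1.9-fold lower number from compound 3 to compound 4 (0.28 log units; within the scatter)), so all four aromatic groups shown fall within it. No measurement offered here accounts for this flat response.

As far as these compounds go, all four groups are aromatic rings, so it remains open whether a morpholine, a carboxylic acid or a longer alkyl chain on this carbon would keep the number at this level.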